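From Isopropylcarbamoyl to Propoxycarbonyl: An Expected Small Step

This account rests on a few compounds, and the source may have more. Where it says the series, first, only, none or still open, it means among the compounds named here.

Measured compounds:
compound 1, `CCOC(=O)c1cc(-c2ccc(OC(=O)NC3CCCCC3)cc2)n(-c2ccc(Cl)cc2)n1` — 281 nM
compound 2, `CC(C)NC(=O)c1cc(-c2cccc(OC(=O)NC3CCCCC3)c2)n(-c2ccccc2)n1` — 232 nM
compound 3, `CCOC(=O)c1cc(-c2ccc(OC(=O)NC3CCCCC3)cc2)nn1-c1ccc(OC)cc1` — 159 nM

All three were tested in an assay on isolated protein for inhibition of Fatty-acid amide hydrolase 1 (Homo sapiens), read by fluorescence, with a stated time of 30 min; on this read-out lower numbers stand for stronger inhibition and higher numbers for weaker inhibition. Compound 2 stands second highest of the three numbers. Its nearest neighbour is compound 1, whose number is within the scatter of repeated measurements, and its furthest is compound 3, which also lies within the scatter. None of the three can be called stronger or weaker than another on these data.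

Compound 4, `CCCOC(=O)c1cc(-c2cccc(OC(=O)NC3CCCCC3)c2)n(-c2ccccc2)n1`, has not been measured. It differs from compound 2 in one place: propoxy in place of isopropylamino on a carbonyl carbon. Among the measured compounds shown here, no pair of measured compounds differs by exactly this change, so no measured step is available for it. What the three measured compounds do show is that the two with an ester at this carbonyl, compound 1 and compound 3, give numbers within the scatter of compound 2, which carries the isopropylamino group there.

On that basis the step of a 1.1-fold higher number from compound 2 to compound 4 (0.03 log units; within the scatter) is expected to stay within the scatter, with no clear direction. For compound 4 the estimated value in this assay is 250 nM, within a range of 110 nM to 600 nM.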

Compound 4, half-maximal inhibitory concentration: 27 nM
Compound 4: middle estimate off by 9.3-fold (0.97 log units), on the high side, and the stated range ends above it.
By their numbers in this assay, from the lowest: compound 4; then compounds 3, 2 and 1 (each within the scatter of the next).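

In this assay, among the compounds shown here, swapping isopropylamino for propoxy on a carbonyl carbon gives an 8.6-fold lower number from compound 2 to compound 4 (0.93 log units; beyond the scatter), the first step here that lies beyond the scatter and the first measured change at this position with everything else held the same. The earlier compounds shown here could not show this: compound 1 and compound 3 also carry an ester at this carbonyl, but they differ from compound 2 in other places as well, so their closeness to it said nothing about this change alone. The result shows that this position is not indifferent to what sits on the carbonyl, although nothing shown gives a measured reason for the step.

The swap alters two things at once, the atom attached to the carbonyl and the isopropyl or propyl chain, so a propylamino or an isopropoxy group at this carbonyl would be needed to tell these two parts apart. Going by these compounds, how a longer chain such as butoxy, or a carboxylic acid at the same place, would read in this assay also stays open.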